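The source may hold more compounds than are shown below. What is called first, only, known or untested is meant among the compounds shown, and "the series" means these compounds.

Series notes. The shared core of compound 1 `CC1CCN(C2CCN(S(=O)(=O)c3cccc(C(F)(F)F)c3)CC2)CC1` carries a sulfonyl aryl group that varies across the set. In a functional assay on DLD-1 cells (Homo sapiens) for antiproliferative activity, read by CellTiter-Glo, with a stated time of 72 h (a lower number here means a stronger inhibitor, a higher number a weaker inhibitor), compound 1 returns only the assay limit, > 5000 nM, not a number. Compound 2 `Cc1cc(C)c(S(=O)(=O)N2CCC(N3CCC(C)CC3)CC2)c(C)c1` gives 0.03 nM in this assay. Compound 3 `CC1CCN(C2CCN(S(=O)(=O)c3cccnc3Cl)CC2)CC1` also stands at the limit of this assay, > 5000 nM, so no number is known for it. Two of the three values shown sit at that limit (the limit of > 5000 nM in this assay, at which 2 of the 3 values shown sit). The move to compound 4 `CC1CCN(C2CCN(S(=O)(=O)c3ccc(F)cc3F)CC2)CC1` is 2,4-difluorophenyl in place of 2-chloropyridin-3-yl on a sulfonyl sulfur. Among the measured compounds shown here, no step between measured compounds is known here, so its size is open; given that compound 1 likewise sits at the limit, no shift beyond the scatter is expected, and the expected step is a step that the limit leaves unreadable from compound 3 to compound 4. Compound 4 is estimated at 6000 nM, within 1500 nM to 20000 nM.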

Compound 4, half-maximal inhibitory concentration: 102 nM
Compound 4: middle estimate off by 59-fold (1.77 log units), on the high side; the measured number lies below the stated range.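

Replacing 2-chloropyridin-3-yl with 2,4-difluorophenyl on the sulfonyl sulfur gives an at least 49-fold lower number from compound 3 to compound 4 (1.69 log units; beyond the scatter) in this assay, so a change at this position alone can bring a compound off the limit. Compound 3 stands at a limit, > 5000 nM, not a number. The step is therefore only a bound because it starts from that limit: the limit of > 5000 nM in this assay, at which 2 of the 4 values shown sit.

From the compounds shown here alone, the swap changes the ring nitrogen, the chlorine and the fluorines together, and which of them carries the step stays open. Going by these compounds, the effect of an amine or a carboxylic acid on this aryl group also stays open.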